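A phenyl-to-pyridyl swap on an anilide

A few compounds are considered here, and "the series" means these few. Any claim that something is new, unique, unknown or untested is made for them only; others in the source may bear on it.

Measured so far in this assay:
compound 1 `Cn1cc(-c2cnc(N)c(Oc3ccc(C(=O)Nc4ccccc4)cc3)n2)cn1`: 11600 nM
compound 2 `Cn1cc(-c2cnc(N)c(Oc3ccc(C(=O)Nc4cccc(Cl)c4)cc3)n2)cn1`: 21200 nM

In a functional assay on HepG2 cells (Homo sapiens) for inhibition, read by MTT assay, with a stated time of 72 h (a higher number here means a weaker inhibitor, a lower number a stronger inhibitor), compound 1 and compound 2 give numbers that lie within the usual scatter of each other, as the step of a 1.8-fold higher number from compound 1 to compound 2 (0.26 log units; within the scatter) shows, so neither can be called the stronger inhibitor. Compound 3 `Cn1cc(-c2cnc(N)c(Oc3ccc(C(=O)Nc4cccc(Cl)n4)cc3)n2)cn1` differs from compound 2 by 6-chloropyridin-2-yl in place of 3-chlorophenyl on an amide-type nitrogen. Among the compounds with values here, no measured step exchanges a ring carbon for nitrogen; the only measured step, a 1.8-fold higher number from compound 1 to compound 2 (0.26 log units; within the scatter), added chlorine, which compound 3 keeps. No step beyond the scatter is therefore expected. Compound 3 is expected to give 21000 nM, with a range from 7000 nM to 60000 nM. The expected step is a 1.0-fold lower number from compound 2 to compound 3 (0.00 log units; within the scatter), inside the scatter.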

Compound 3, half-maximal inhibitory concentration: 44200 nM
Beside the measured number, compound 3's estimate is 2.1-fold (0.32 log units) below it; measured number inside the range.
By their numbers in this assay, from the lowest: compounds 1 and 2 (each within the scatter of the next); then compound 3.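

In this assay, within the data shown here, 6-chloropyridin-2-yl in place of 3-chlorophenyl on the amide-type nitrogen gives a weaker inhibitor, a 2.1-fold higher number from compound 2 to compound 3 (0.32 log units; beyond the scatter), the first step at this position to pass the scatter. Set against the plain phenyl, the same group gives a 3.8-fold higher number from compound 1 to compound 3 (0.58 log units; beyond the scatter), so this position does respond to a change, though only modestly. Nothing measured here gives a reason for this shift.

Still open, on these data alone, is how a pyridin-2-yl ring without the chlorine would compare with the plain phenyl. Also open, as far as these compounds go, is whether an amine or a methoxy group in place of the chlorine would give a stronger inhibitor.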